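This account rests on a few compounds, and the source may have more. Where it says the series, first, only, none or still open, it means among the compounds named here.

Measured so far in a functional assay on MDA-MB-231 cells (Homo sapiens) for antiproliferative activity, read by MTT assay, with a stated time of 48 h; a higher number here means a weaker inhibitor, a lower number a stronger inhibitor:
- compound 1 `COc1ccc(N(C)c2cc(C)nc(C)n2)cc1`: 3650 nM
- compound 2 `COc1ccc(N(C)c2cc(C)nc(C)n2)cc1Cl`: 1900 nM

Compound 2, at 1900 nM, cannot be separated from compound 1 on these numbers. The next structure is compound 3 `COc1ccc(N(C)c2cc(C)nc(C)n2)cc1O`, with hydroxy in place of chloro on an aromatic carbon, ortho to a methoxy group. Among the measured compounds shown here, no measured step involves hydroxy. For the measured compounds named here, the only step at this place is a 1.9-fold lower number from compound 1 to compound 2 (0.28 log units; within the scatter), so no change beyond the scatter is expected in this assay, and the direction stays open. The expected step is a 1.1-fold lower number from compound 2 to compound 3 (0.05 log units; within the scatter). For compound 3 the estimated value is 1700 nM, with an expected range of 450 nM to 5500 nM.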

Compound 3, half-maximal inhibitory concentration: 1100 nM
For compound 3 the middle estimate is 1.5-fold (0.19 log units) above the measured one, within the range that was stated.
By their numbers in this assay, from the lowest: compounds 3, 2 and 1 (each within the scatter of the next, the first and the last beyond it).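

Among the compounds shown here, with hydroxy on this aromatic carbon, ortho to a methoxy group, this assay shows a step beyond the scatter from the hydrogen compound for the first time, with a 3.3-fold lower number from compound 1 to compound 3 (0.52 log units; beyond the scatter) as the result. Hydroxy and chloro remain unseparated at this place, with a 1.7-fold lower number from compound 2 to compound 3 (0.24 log units; within the scatter) inside the scatter. No available evidence bears on this result.

On these data alone, whether an amine or fluoro at this place would match hydroxy remains open. So does whether the step from hydrogen to hydroxy holds with the methoxy group replaced by an ethoxy group.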